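The source may hold more compounds than are shown below. What is called first, only, known or untested is meant among the compounds shown, and "the series" means these compounds.

Measured compounds:
compound 1 `COc1cc2ncnc(N3CCc4ccccc43)c2cc1NC(=O)C=C(C)C` with 6390 nM
compound 2 `CCC/C=C/C(=O)Nc1cc2c(N3CCc4ccccc43)ncnc2cc1OC` with 3160 nM
compound 3 `CCC/C=C/C(=O)Nc1cc2c(N3CCc4ccccc43)ncnc2cc1O[C@@H]1CCOC1` with 4550 nM

In a functional assay on MCF7 cells (Homo sapiens) for antiproliferative activity, read by MTT assay, with a stated time of 72 h (a higher number here means a weaker inhibitor, a lower number a stronger inhibitor), compound 2 gives the lowest of the three numbers; compound 3 sits closest to it, and the gap between them is within the scatter, while compound 1 sits furthest away. The step of a 2.0-fold lower number from compound 1 to compound 2 (0.31 log units; beyond the scatter) is modest but beyond the scatter; the step of a 1.4-fold higher number from compound 2 to compound 3 (0.16 log units; within the scatter) is within the scatter. Compound 4 `COc1cc2ncnc(N3CCc4ccccc43)c2cc1NC(=O)/C=C/CN1CCN(C)CC1` keeps the methyl on the ring oxygen of compound 2 and changes only the chain: 4-methylpiperazin-1-yl in place of ethyl on a saturated chain carbon bound to a double-bonded chain carbon. Going by the values given here, no measured step alters this part of the chain in the same way. The step of a 2.0-fold lower number from compound 1 to compound 2 (0.31 log units; beyond the scatter) shows that a change in the unsaturated amide tail shifted this assay only modestly, and the step of a 1.4-fold higher number from compound 2 to compound 3 (0.16 log units; within the scatter) does not concern the chain at all, so nothing here points to a large move in either direction. The expected step is therefore a 1.1-fold lower number from compound 2 to compound 4 (0.02 log units; within the scatter), not beyond the scatter. Compound 4 is estimated at 3000 nM in this assay, within the range 1000 nM to 9000 nM.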

Compound 4, half-maximal inhibitory concentration: 6430 nM
Beside the measured number, compound 4's estimate is 2.1-fold (0.33 log units) below it, and the stated range covers the measured number.
By their numbers in this assay, from the lowest: compounds 2, 3, 1 and 4 (each within the scatter of the next, the first and the last beyond it).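

In this assay, going by these compounds alone, the saturated chain carbon bound to a double-bonded chain carbon takes 4-methylpiperazin-1-yl in place of ethyl with a 2.0-fold higher number from compound 2 to compound 4 (0.31 log units; beyond the scatter) as the result, so the only change measured at this place moves the number modestly, and towards a weaker inhibitor. Set against the branched tail, the same chain gives a 1.0-fold higher number from compound 1 to compound 4 (0.00 log units; within the scatter) and this places 3-(4-methylpiperazin-1-yl)prop-1-en-1-yl and 2-methylprop-1-en-1-yl on a carbonyl carbon level within the scatter. Nothing measured here accounts for the step from ethyl to 4-methylpiperazin-1-yl.

On these data alone, whether a morpholine ring, a dimethylamino group or a longer chain at the same carbon would give a number like that of compound 4 stays open. So does whether 4-methylpiperazin-1-yl would have the same effect with the oxolan-3-yl group of compound 3 on the ring oxygen.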